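Series notes: arylpiperazine-ethyl indoles at the serotonin-7 receptor

The source may hold more compounds than are shown below. What is called first, only, known or untested is meant among the compounds shown, and "the series" means these compounds.

Measured so far:
compound 1 `Cc1ccc2ccn(CCN3CCCN(C)CC3)c2c1` gives 62% in an assay on HEK293 cells for binding affinity to 5-hydroxytryptamine receptor 7 (Homo sapiens), read by radioligand binding, tested at 1 uM; a higher number here means more inhibition at the concentration tested (going by the name of the read-out), a lower number less inhibition
compound 2 `CN1CCCN(CCn2ccc3ccc(C(C)(C)O)cc32)CC1` gives 6% in this assay

Compound 2 stands lowest of the two measured values; compound 1 is its nearest neighbour and lies higher. Among the measured compounds shown here, the step of a number 56 percentage points lower from compound 1 to compound 2 (beyond the scatter) is the only measured step, and it concerns the same aromatic carbon that is changed next.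

Compound 3 `CN1CCCN(CCn2ccc3ccc(-c4ccsc4)cc32)CC1` differs from compound 2 by thiophen-3-yl in place of 1-hydroxy-1-methylethyl on an aromatic carbon. For the measured compounds named here, the group that leaves is the one whose entry cost the large drop from compound 1 to compound 2, so its removal is expected to recover part of that loss; the incoming thiophen-3-yl has no measured precedent here. The expected step is a number 34 percentage points higher from compound 2 to compound 3 (beyond the scatter), upward and beyond the scatter, giving an estimate for compound 3 of 40%, with a range from 10% to 70%.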

Compound 3, a percentage reported as inhibition, at one concentration (the size of the read-out at that concentration, not a potency): 68%
Compound 3: the middle estimate sits 28 percentage points below what was measured; low and high end bracket the measured number.
By their numbers in this assay, from the lowest: compound 2; then compounds 1 and 3 (each within the scatter of the next).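

In this assay the change gives a number 62 percentage points higher from compound 2 to compound 3 (beyond the scatter) and so shows that this aromatic carbon can carry a ring substituent with no hydrogen-bond donor, so the low number of compound 2 does not extend to every group larger than methyl. Against methyl, the change gives a number 6 percentage points higher from compound 1 to compound 3 (within the scatter) and so separates thiophen-3-yl from methyl by no more than the usual scatter. Nothing available explains why the two larger groups part so widely here.

Open, as far as these compounds go, is whether the hydroxyl or the branched carbon of 1-hydroxy-1-methylethyl goes with the low number of compound 2. Also open, from the compounds shown here alone, is how a phenyl ring, a primary amine or a carboxylic acid would fare on this carbon.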